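The compounds below may be only part of what the source reports. "The series", "measured", "known", "first", "only" and "open" are said of these compounds alone.

Measured in a functional assay on brain (Rattus norvegicus, strain Wistar) for inhibition; a higher number here means a weaker inhibitor, a lower number a stronger inhibitor:
Compound 1 `Cc1[nH]c(=O)n(C)c1-c1ccccc1` gives > 100000 nM, which is a limit of the assay.
Compound 2 `CCCCc1ccc(-c2c(C)[nH]c(=O)n2C)cc1` gives 10700 nM.
Compound 3 `CCCCCCOc1ccc(-c2c(C)[nH]c(=O)n2C)cc1` gives 7300 nM.

Compound 2 holds the highest of the two numbers shown, with compound 3 nearest, a 1.5-fold lower number from compound 2 to compound 3 (0.17 log units; within the scatter), a gap within the scatter. Compound 4 `CCCCCCCc1ccc(-c2c(C)[nH]c(=O)n2C)cc1` is not yet measured; it differs from compound 2 by propyl in place of hydrogen on a saturated chain carbon, four bonds along the chain from an aromatic carbon. Going by the values given here, two measured steps bear on this: an at least 9.3-fold lower number from compound 1 to compound 2 (0.97 log units; beyond the scatter) and an at least 13-fold lower number from compound 1 to compound 3 (1.13 log units; beyond the scatter), both from adding a chain to the aromatic carbon, whereas a 1.5-fold lower number from compound 2 to compound 3 (0.17 log units; within the scatter) shows that a longer chain adds little once one is present. Extending butyl to heptyl is therefore expected to give a small step toward a lower number in this assay, a 1.8-fold lower number from compound 2 to compound 4 (0.25 log units; within the scatter). Compound 4 is estimated at 6000 nM, range 2000 nM to 15000 nM.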

Compound 4, half-maximal inhibitory concentration: 8400 nM
For compound 4 the middle estimate is 1.4-fold (0.15 log units) below the measured one; the measured number falls inside the stated range.
By their numbers in this assay, from the lowest: compounds 3, 4 and 2 (each within the scatter of the next). At a limit, above all of these: compound 1.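

In this assay, propyl on a saturated chain carbon, four bonds along the chain from an aromatic carbon, gives a 1.3-fold lower number from compound 2 to compound 4 (0.11 log units; within the scatter), so butyl and heptyl are not told apart here. Heptyl in place of hexyloxy gives a 1.2-fold higher number from compound 3 to compound 4 (0.06 log units; within the scatter), so these two chains are not told apart either. Heptyl in place of hydrogen gives an at least 11-fold lower number from compound 1 to compound 4 (1.07 log units; beyond the scatter), and the true size of that step stays open: the limit of > 100000 nM in this assay, at which 1 of the 4 values shown sits.

Still open, on these data alone, is whether a shorter chain such as methyl already reaches this range, and whether a chain carrying an amine or a carboxylic acid stays within it.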